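The compounds below may be only part of what the source reports. "The series", "measured", "known", "first", "only" and "open" are said of these compounds alone.

Measured compounds:
compound 1, `C=C/C=C\[C@H](C)[C@H](OC(N)=O)[C@@H](C)[C@H](O)[C@@H](C)C/C(C)=C\[C@H](C)[C@@H](O)[C@@H](C)/C=C\CCc1cccc(F)c1`: 370 nM
compound 2, `C=C/C=C\[C@H](C)[C@H](OC(N)=O)[C@@H](C)[C@H](O)[C@@H](C)C/C(C)=C\[C@H](C)[C@@H](O)[C@@H](C)/C=C\CCc1ccc(C)c(O)c1`: 770 nM
compound 3, `C=C/C=C\[C@H](C)[C@H](OC(N)=O)[C@@H](C)[C@H](O)[C@@H](C)C/C(C)=C\[C@H](C)[C@@H](O)[C@@H](C)/C=C\CCc1ccccc1`: 480 nM

In a functional assay on MCF7 cells (Homo sapiens) for cytotoxicity (on this read-out lower numbers stand for stronger inhibition and higher numbers for weaker inhibition), compound 1 holds the lowest of the three numbers. Compound 3 lies within the scatter of it, as the step of a 1.3-fold higher number from compound 1 to compound 3 (0.11 log units; within the scatter) shows, while compound 2 lies beyond it, by a 2.1-fold higher number from compound 1 to compound 2 (0.32 log units; beyond the scatter).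

Compound 4, `C=C/C=C\[C@H](C)[C@H](OC(N)=O)[C@@H](C)[C@H](O)[C@@H](C)C/C(C)=C\[C@H](C)[C@@H](O)[C@@H](C)/C=C\CCc1cccc(O)c1`, differs from compound 1 in one place: hydroxy in place of fluoro on an aromatic carbon. Going by the values given here, two measured steps bear on this change. Removing the fluoro in a 1.3-fold higher number from compound 1 to compound 3 (0.11 log units; within the scatter) changed little, whereas bringing in a hydroxy together with a methyl in a 2.1-fold higher number from compound 1 to compound 2 (0.32 log units; beyond the scatter) gave a modest rise. A hydroxy alone is therefore expected to give compound 4 a modest rise of about a 1.6-fold higher number from compound 1 to compound 4 (0.21 log units; within the scatter), and compound 4 is estimated at 600 nM, with a range from 300 nM to 1200 nM.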

Compound 4, half-maximal inhibitory concentration: 130 nM
Estimate against measurement, compound 4: 4.6-fold (0.66 log units) above, and the stated range ends above it.
By their numbers in this assay, from the lowest: compound 4; then compounds 1, 3 and 2 (each within the scatter of the next, the first and the last beyond it).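

In this assay, the hydroxy alone lowers the number at this aromatic carbon, giving a 2.8-fold lower number from compound 1 to compound 4 (0.45 log units; beyond the scatter) against fluoro and a 3.7-fold lower number from compound 3 to compound 4 (0.57 log units; beyond the scatter) against hydrogen, although fluoro and hydrogen had stayed within the scatter of each other. The added methyl of compound 2 goes against this gain, as removing it gives a 5.9-fold lower number from compound 2 to compound 4 (0.77 log units; beyond the scatter) and compound 2 had stayed within the scatter of the unsubstituted phenyl of compound 3. Nothing available explains the gain. Still open, as far as these compounds go, is whether a methoxy or an amine at this carbon would keep it, and whether a hydroxy elsewhere on the ring would do the same.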